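Fluoro for hydrogen on the phenyl ring: working notes

The source may hold more compounds than are shown below. What is called first, only, known or untested is meant among the compounds shown, and "the series" means these compounds.

Measured so far:
compound 1 `COc1cc(OC)cc(-n2c(-c3ccccc3)nc(C)c2C)c1` — 55.2%
compound 2 `COc1ccc(-n2c(-c3ccc(F)cc3)nc(C)c2C)cc1` — 50.6%
compound 3 `COc1ccc(-n2c(-c3ccccc3)nc(C)c2C)cc1` — 50.6%

In a functional assay, read by spectrophotometry, with a stated time of 60 min, tested at 80 uM (a lower number here means a weaker effect, a higher number a stronger effect of the compound at the concentration tested), compound 1 gives 55.2%, compound 2 gives 50.6% and compound 3 gives 50.6%. Compound 1 carries the highest of the three numbers, yet both gaps to it lie within the scatter, so no ordering is claimed. Compound 4 `COc1cc(OC)cc(-n2c(-c3ccc(F)cc3)nc(C)c2C)c1` differs from compound 1 by fluoro in place of hydrogen on an aromatic carbon. Among the measured compounds shown here, one measured step bears on this change, the same exchange run the other way: no change at the digits printed from compound 2 to compound 3 (within the scatter). That step was flat, so no shift beyond the scatter is expected here either. Compound 4 is therefore expected to give 55%, with a range from 43% to 67%. The step expected from this estimate is a number 0.2 percentage points lower from compound 1 to compound 4 (within the scatter).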

Compound 4, a percentage reported as activity, at one concentration (the size of the read-out at that concentration, not a potency): 55.2%
Beside the measured number, compound 4's estimate is 0.2 percentage points below it; low and high end bracket the measured number.
By their numbers in this assay, from the lowest: compounds 2, 3, 1 and 4 (each within the scatter of the next).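

In this assay, the step for fluoro in place of hydrogen, para to a large group, reads no change at the digits printed from compound 1 to compound 4 (within the scatter). This position now has a reading on a second core, and the flat result no longer rests on a single pair of compounds. The change reads the same on both cores: the same change on two cores in this assay, no change at the digits printed (within the scatter) from compound 2 to compound 3 and no change at the digits printed (within the scatter) from compound 4 to compound 1, 0 percentage points apart, within the scatter of two such steps

The compounds shown carry only hydrogen or fluoro at this position, so it remains open whether a larger replacement would move the number. An amine, a carboxylic acid or a longer chain in this place would test that.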